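Replacing a carbamate chain by benzyl on a diaziridinyl quinone core

A few compounds are considered here, and "the series" means these few. Any claim that something is new, unique, unknown or untested is made for them only; others in the source may bear on it.

The account follows two compounds measured in a functional assay on L1210 cells (Mus musculus), with a stated time of 1 days (a higher number here means a more potent compound, by a factor of ten per unit of this negative logarithm, a lower number a less potent compound), and one that awaits measurement. Compound 1, `CC1=C(N2CC2)C(=O)C(CC(C)OC(N)=O)=C(N2CC2)C1=O`, gives 5.18 and stands highest of the two numbers shown. Compound 2, `CCCC1=C(N2CC2)C(=O)C(CCOC(N)=O)=C(N2CC2)C1=O`, gives 4.42 in this assay, a number lower than that of compound 1 by a margin that lies beyond the usual scatter. For the measured compounds named here, compound 2 differs from compound 1 in more than one place, so no single step between them can be read from the two values; they show only that compound 1 is the more potent of the pair.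

The compound still to be measured is compound 3, `CC1=C(N2CC2)C(=O)C(Cc2ccccc2)=C(N2CC2)C1=O`. Its departure from compound 1 is a group of 6 heavy atoms (6 carbon; one six-membered aromatic ring of carbon only) in place of a group of 6 heavy atoms (3 carbon, 1 nitrogen, 2 oxygen; no ring), on a saturated chain carbon bound to a double-bonded ring carbon. Going by the values given here, no step of the same kind has been measured among the compounds at hand, so the size and direction of the change rest on expectation alone. Compound 3 is expected to give 4.7 in this assay, within a range from 4 to 5.4, the expected step being a number 0.48 log units lower from compound 1 to compound 3 (beyond the scatter), a modest loss that may not exceed the scatter.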

Compound 3, logarithm of the reciprocal of the active concentration, log(1/C): 4.26
Estimate against measurement, compound 3: 0.44 log units above, within the range that was stated.
By their numbers in this assay, from the lowest: compounds 3 and 2 (each within the scatter of the next); then compound 1.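

For the compounds shown here, the pair gives the first step that can be read at this position: in this assay, phenyl in place of the open chain, on a saturated chain carbon bound to a double-bonded ring carbon, comes with a number 0.92 log units lower from compound 1 to compound 3 (beyond the scatter). The two groups match in heavy-atom count, yet phenyl, with 0 hydrogen-bond donors and 0 hydrogen-bond acceptors, does not keep the number of compound 1, so on this core the count of heavy atoms in the group does not by itself set the value. Nothing measured here bears on the reason for this drop.

Going by these compounds alone, with only this pair, the removal of the chain and the arrival of the aromatic ring cannot be told apart, as both happen in the one step. Going by these compounds, how a cyclohexyl group, which keeps a ring of the same size without aromaticity, or a hydroxyl or an amine at the end of a short chain, would read at this place in this assay remains open.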